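A few compounds are considered here, and "the series" means these few. Any claim that something is new, unique, unknown or untested is made for them only; others in the source may bear on it.

Measured so far:
compound 1 `Fc1ccccc1Nc1nc2nonc2nc1NCCC(F)(F)F` — > 100000 nM
compound 2 `Fc1ccc(Nc2nc3nonc3nc2Nc2ccccc2F)cc1` — 2300 nM
compound 3 `CCOc1ccccc1Nc1nc2nonc2nc1Nc1ccccc1F` — 5600 nM

In an assay on mitochondria from L6 cells (Rattus norvegicus) for activation, with a stated time of 90 min (on this read-out higher numbers stand for an effect only at larger amounts of compound and lower numbers for an effect already at smaller amounts), compound 1 gives only a limit of the assay, > 100000 nM. Compound 2 gives 2300 nM, the lowest of the two numbers shown; compound 3 gives 5600 nM. Compound 4 `Fc1ccccc1Nc1nc2nonc2nc1Nc1ccc(OC(F)(F)F)cc1` is not yet measured. Compared with compound 2 it differs in one place: trifluoromethoxy in place of fluoro on an aromatic carbon. Of the measured steps, a 2.4-fold higher number from compound 2 to compound 3 (0.39 log units; beyond the scatter) bears most on this change, as it also swaps one substituted phenyl for another on the same nitrogen; the steps of an at least 43-fold lower number from compound 1 to compound 2 (1.63 log units; beyond the scatter) and an at least 17-fold lower number from compound 1 to compound 3 (1.25 log units; beyond the scatter) are large but replace a chain with a ring. A modest step, or none beyond the scatter, is therefore expected. Compound 4 is expected to give about 3000 nM, between 800 nM and 12000 nM, a step of a 1.3-fold higher number from compound 2 to compound 4 (0.12 log units; within the scatter).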

Compound 4, half-maximal effective concentration: 1300 nM
The estimate for compound 4 lay 2.3-fold (0.36 log units) above the measured number; the measured number falls inside the stated range.
By their numbers in this assay, from the lowest: compounds 4 and 2 (each within the scatter of the next); then compound 3. At a limit, above all of these: compound 1.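

In this assay trifluoromethoxy in place of fluoro on this aromatic carbon gives a 1.8-fold lower number from compound 2 to compound 4 (0.25 log units; within the scatter). This position, para to a large group, therefore accepts 5 heavy atoms and 1 hydrogen-bond acceptor in place of a single fluorine with no step beyond the scatter. The earlier steps shown here exchanged the whole group on a nitrogen, whereas this one changes a single substituent on the ring and leaves the rest of the compound as it was. As far as these compounds go, whether an amine or a carboxylic acid on this carbon would also stay within the scatter remains open. Nothing shown here accounts for the result.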